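This account rests on a few compounds, and the source may have more. Where it says the series, first, only, none or still open, it means among the compounds named here.

Of the compounds shown here, three of a shared series have been measured in a functional assay on IMR-32 cells for inhibition of Voltage-dependent N-type calcium channel subunit alpha-1B (Homo sapiens), read by calcium flux; on this read-out lower numbers stand for stronger inhibition and higher numbers for weaker inhibition. Compound 1 `COc1ccc(COC(=O)[C@@H](CC(=O)OC2CCCC2)NC(=O)OC(C)(C)C)cc1` gives 2000 nM, and compound 2 `CC(C)(C)OC(=O)N[C@@H](CC(=O)OC1CCCC1)C(=O)OCc1ccc(Cl)cc1` gives 3300 nM. Compound 3 `COc1ccc(COC(=O)[C@H](CC(=O)OC2CCC2)NC(=O)OC(C)(C)C)cc1` stands at the top of these numbers with 15000 nM, which lies beyond the scatter of the other two values. The next compound, compound 4 `COc1ccc(COC(=O)[C@H](CC(=O)OC2CCCC2)NC(=O)OC(C)(C)C)cc1`, differs from compound 3 by a single change: cyclopentyl in place of cyclobutyl on an oxygen next to a carbonyl group. Among the compounds with values here, no step between measured compounds isolates this change, so the expected size of the step rests on judgement alone; a modest move towards a lower number, beyond the scatter, seems the more likely outcome. The step from compound 3 to compound 4 is therefore estimated at a 3.0-fold lower number from compound 3 to compound 4 (0.48 log units; beyond the scatter). On this basis compound 4 is expected to give about 5000 nM in this assay, within a range from 1500 nM to 15000 nM.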

Compound 4, half-maximal inhibitory concentration: 3400 nM
Estimate against measurement, compound 4: 1.5-fold (0.17 log units) above; the range from low to high includes it.
By their numbers in this assay, from the lowest: compounds 1, 2 and 4 (each within the scatter of the next); then compound 3.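

With the step of a 4.4-fold lower number from compound 3 to compound 4 (0.64 log units; beyond the scatter), cyclopentyl in place of cyclobutyl on an oxygen next to a carbonyl group is the only change shown here that lies beyond the scatter. Methoxy in place of chloro on an aromatic carbon gives a 1.0-fold higher number from compound 2 to compound 4 (0.01 log units; within the scatter), so this swap leaves the number within the scatter. The stereocentre at a saturated chain carbon likewise gives a 1.7-fold higher number from compound 1 to compound 4 (0.23 log units; within the scatter), a comparison that isolates configuration: the fact that compounds 1 and 4 differ only in the configuration as drawn

The compounds shown leave open how a cyclohexyl ring or an open chain such as isopropyl would read on that oxygen. They also leave open what a free carboxylic acid would give there.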